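This account rests on a few compounds, and the source may have more. Where it says the series, first, only, none or still open, it means among the compounds named here.

Series, measured in a functional assay on the whole organism (Tail, strain ICR) with Mus musculus as the target, in the tail flick test, with a stated time of 120 min, at a dose of 25 umol/kg by the oral route; a higher number here means a stronger effect of the compound at the dose given, a lower number a weaker effect:
- compound 1 `NC(=O)CC[C@H](NC(=O)CN(c1ncnc2c1ncn2C1CCCCO1)C1CC1)C(=O)OCc1ccccc1` gives 22.3%
- compound 2 `N=C(N)NCCC[C@H](NC(=O)CN(c1ncnc2c1ncn2C1CCCCO1)C1CC1)C(=O)OCc1ccccc1` gives 38.2%
- compound 3 `CC(C)C[C@H](NC(=O)CN(c1ncnc2c1ncn2C1CCCCO1)C1CC1)C(=O)OCc1ccccc1` gives 12.8%

Compound 3 stands lowest of the three numbers; its nearest neighbour is compound 1, with the step of a number 9.5 percentage points lower from compound 1 to compound 3 (within the scatter) lying within the scatter, while the step of a number 25.4 percentage points lower from compound 2 to compound 3 (beyond the scatter) lies beyond it. The step of a number 15.9 percentage points higher from compound 1 to compound 2 (beyond the scatter) shows that a change of the side-chain group at this part of the shared core can move the read-out, though only modestly.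

Compound 4 `CC(C)[C@H](NC(=O)CN(c1ncnc2c1ncn2C1CCCCO1)C1CC1)C(=O)OCc1ccccc1` is to be measured in this assay. The change is isopropyl in place of isobutyl on a saturated chain carbon bound to an amide-type nitrogen and a carbonyl carbon. Among the compounds with values here, no measured step exchanges one hydrocarbon side chain for another; the nearest comparison, a number 9.5 percentage points lower from compound 1 to compound 3 (within the scatter), replaces a group holding nitrogen and oxygen with isopropyl and stays within the scatter. Removing one carbon from the isobutyl of compound 3 is a smaller change than any of the measured steps, so no step beyond the scatter is expected, in either direction. Compound 4 is therefore expected to give 13%, within 3% to 26%, which would mean an expected step of a number 0.2 percentage points higher from compound 3 to compound 4 (within the scatter).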

Compound 4, a percentage reported as activity, at one dose (the size of the read-out at that dose, not a potency): 25.8%
Beside the measured number, compound 4's estimate is 12.8 percentage points below it, and the stated range covers the measured number.
By their numbers in this assay, from the lowest: compounds 3, 1 and 4 (each within the scatter of the next, the first and the last beyond it); then compound 2.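

In this assay, isopropyl in place of isobutyl (a number 13 percentage points higher from compound 3 to compound 4 (beyond the scatter)) shows that this position separates even two hydrocarbon side chains with no hydrogen-bond donors or acceptors. Isopropyl is not separated from the 2-carbamoylethyl of compound 1 (a number 3.5 percentage points higher from compound 1 to compound 4 (within the scatter)), while the side chain of compound 2 keeps the higher number (a number 12.4 percentage points lower from compound 2 to compound 4 (beyond the scatter)), so a side chain with no nitrogen can match one carrying an amide but not the one in compound 2. No evidence on the cause of these steps is at hand.

From the compounds shown here alone, it remains open whether the number keeps rising with a smaller hydrocarbon group such as methyl, or changes with a ring such as phenyl or cyclohexyl. Going by these compounds, it is also open whether an amine or a carboxylic acid on this side chain would reach the number of compound 2.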